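Halogen swap on an anilide, repeated on a deprotected core

The source may report more compounds than this note shows. Statements on the series, on what has been measured and on what is new or still open speak of the compounds shown alone.

Of the compounds shown here, three have been tested in a functional assay on K562/Adr cells (Homo sapiens) for inhibition, read by MTT assay, with a stated time of 48 h, tested at 30 uM; a lower number here means less inhibition, a higher number more inhibition at the concentration tested (going by the name of the read-out). Compound 1, `CC(C)(C)OC(=O)N1C[C@@H](n2cc(-c3ccc4c(N)n[nH]c4c3)nn2)C[C@H]1C(=O)Nc1ccc(Cl)cc1Cl`, gives 25.6% in this assay. Compound 2, `CC(C)(C)OC(=O)N1C[C@@H](n2cc(-c3ccc4c(N)n[nH]c4c3)nn2)C[C@H]1C(=O)Nc1ccc(Br)cc1`, carries the change 4-bromophenyl in place of 2,4-dichlorophenyl on an amide-type nitrogen and gives 23% in this assay, so that the measured step is a number 2.6 percentage points lower from compound 1 to compound 2 (within the scatter). Compound 3, `Nc1n[nH]c2cc(-c3cn([C@@H]4CN[C@H](C(=O)Nc5ccc(Cl)cc5Cl)C4)nn3)ccc12`, differs from compound 1 by hydrogen in place of tert-butoxycarbonyl on an amine nitrogen in a ring; in this assay compound 3 gives 29.4%, and the step here is a number 3.8 percentage points higher from compound 1 to compound 3 (within the scatter). Compound 2 and compound 3 are not joined by a single change, and their two values lie within the usual scatter of each other.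

Compound 4, `Nc1n[nH]c2cc(-c3cn([C@@H]4CN[C@H](C(=O)Nc5ccc(Br)cc5)C4)nn3)ccc12`, has not yet been tested. It stands to compound 3 as compound 2 stands to compound 1, with the change (4-bromophenyl in place of 2,4-dichlorophenyl on an amide-type nitrogen), and the place of that change is described in the same words in both pairs, so it is the same change made on a core that differs by hydrogen in place of tert-butoxycarbonyl on an amine nitrogen in a ring. Within the data shown here, the one earlier example of this change, from compound 1 to compound 2, was a step that stayed within the scatter.

The step expected from compound 3 to compound 4 is therefore estimated as a number 2.4 percentage points lower from compound 3 to compound 4 (within the scatter), resting on the earlier step of a number 2.6 percentage points lower from compound 1 to compound 2 (within the scatter). In this assay compound 4 is expected to give about 27%, with a plausible range from 17% to 37%.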

Compound 4, a percentage reported as inhibition, at one concentration (the size of the read-out at that concentration, not a potency): 26.8%
For compound 4 the middle estimate is 0.2 percentage points above the measured one; the measured number falls inside the stated range.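

In this assay, putting 4-bromophenyl in place of 2,4-dichlorophenyl on the core without tert-butoxycarbonyl gives a number 2.6 percentage points lower from compound 3 to compound 4 (within the scatter), and this agrees with the same change on the protected core: the same change on two cores in this assay, a number 2.6 percentage points lower (within the scatter) from compound 1 to compound 2 and a number 2.6 percentage points lower (within the scatter) from compound 3 to compound 4, 0 percentage points apart, within the scatter of two such steps. Read the other way around the same four compounds, hydrogen in place of tert-butoxycarbonyl on the amine nitrogen in the ring gives a number 3.8 percentage points higher from compound 2 to compound 4 (within the scatter), and this also agrees with its earlier counterpart: the same change on two cores in this assay, a number 3.8 percentage points higher (within the scatter) from compound 1 to compound 3 and a number 3.8 percentage points higher (within the scatter) from compound 2 to compound 4, 0 percentage points apart, within the scatter of two such steps. Each change therefore behaves alike on the two cores shown, but every step lies within the scatter, so this is agreement between steps that cannot be told apart from repeat-to-repeat variation, and it does not show that either change has a real effect or that a change with a larger effect would carry over as faithfully.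

The compounds shown leave open whether a step beyond the scatter could arise from a different group on the amide-type nitrogen, such as a methoxyphenyl or a pyridyl, or from an acetyl group or a methyl group on the amine nitrogen in the ring. They also leave open how potency compares across the series, since a reading at one concentration is not a potency.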